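The compounds below may be only part of what the source reports. "The series", "measured", "known", "first", "only" and "open" are said of these compounds alone.

Compound 1 `Cc1ccc(S(=O)(=O)Nc2ccc(-c3nc4ccccc4o3)cc2)cc1` is the starting point. In an ADME assay on HEK293 cells (Homo sapiens) for cytotoxicity, read by resazurin assay, with a stated time of 48 h (a higher number here means that more compound is tolerated, a lower number that less compound is tolerated), compound 1 gives 88000 nM. Compound 2 `C=Cc1ccc(S(=O)(=O)Nc2ccc(-c3nc4ccccc4o3)cc2)cc1` carries a vinyl in place of the methyl on an aromatic carbon. In this assay compound 2 reaches only a limit of the assay, > 100000 nM, rather than a measured number. Between the two there is an at least 1.1-fold higher number from compound 1 to compound 2 (0.05 log units; that floor lies within the scatter), and the figure for compound 2 is a floor set by the limit of > 100000 nM in this assay, at which 1 of the 2 values shown sits. On the numbers shown, compound 2 therefore stands at or beyond the top of the measured range, with compound 1 the only compound holding an actual number.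

Compound 3 `O=S(=O)(Nc1ccc(-c2nc3ccccc3o2)cc1)c1ccc(Cl)c(Cl)c1` differs from compound 2 by 3,4-dichlorophenyl in place of 4-vinylphenyl on a sulfonyl sulfur. Among the measured compounds shown here, the only measured step, an at least 1.1-fold higher number from compound 1 to compound 2 (0.05 log units; that floor lies within the scatter), concerns a different change and was small, so it gives little guidance for exchanging 4-vinylphenyl for 3,4-dichlorophenyl. No direction beyond the scatter can be asserted from these data. The step is expected to be roughly an at least 1.5-fold lower number from compound 2 to compound 3 (0.18 log units; that floor lies within the scatter). Compound 3 is estimated at 65000 nM, within a range from 20000 nM to 150000 nM, and it may again sit at the limit.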

Compound 3, half-maximal cytotoxic concentration: > 100000 nM
Compound 3: a limit, no number; the forecaster's own chance of this, stated with the estimate: 35%; middle value at least 1.5-fold (0.18 log units) from the limit.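

At this place on the sulfonyl sulfur, a third group, 3,4-dichlorophenyl, now stands alongside 4-methylphenyl and 4-vinylphenyl, and in this assay compound 3 also stops at a limit rather than at a number. Among the compounds shown here, the one step that can be read, an at least 1.1-fold higher number from compound 1 to compound 3 (0.05 log units; that floor lies within the scatter), is only a floor within the scatter, so it fixes no direction for exchanging 4-methylphenyl for 3,4-dichlorophenyl. The step from compound 2 to compound 3 cannot be read, because both compounds stop at a limit: the limit of > 100000 nM in this assay, at which 2 of the 3 values shown sit.

As far as these compounds go, how far compound 2 and compound 3 lie beyond that limit stays open, and so does any order between them. Also open, from the compounds shown here alone, is how a phenyl carrying an amine or a carboxylic acid, on the same sulfonyl sulfur, would read in this assay.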